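The source may hold more compounds than are shown below. What is called first, only, known or untested is meant among the compounds shown, and "the series" means these compounds.

Compound 3 `CN1CCN(c2ccc(Nc3ncc4nc(Nc5ccc(F)cc5)n([C@H]5CCCN(C(=O)CO)C5)c4n3)cc2)CC1` is the weaker of the two compounds with a number in a functional assay on NCI-H1975 cells (Homo sapiens) for antiproliferative activity, read by MTT assay, with a stated time of 72 h; a higher number here means a weaker inhibitor, a lower number a stronger inhibitor: in this assay compound 3 gives 750 nM, while compound 1 `CN1CCN(c2ccc(Nc3ncc4nc(Nc5ccccc5)n([C@H]5CCN(S(=O)(=O)C6CC6)C5)c4n3)cc2)CC1` gives 240 nM, a gap that lies beyond the usual scatter. Compound 2 `CCOC(=O)CN1CC[C@H](n2c(Nc3ccc(F)cc3)nc3cnc(Nc4ccc(N5CCN(C)CC5)cc4)nc32)C1` belongs to the same series, but in this assay compound 2 is recorded only as "not determined" (no result reported), so it contributes no number.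

Compound 4 `CN1CCN(c2ccc(Nc3ncc4nc(Nc5ccc(F)cc5)n([C@H]5CCN(S(=O)(=O)C6CC6)C5)c4n3)cc2)CC1` is the next step from compound 3. The change is 1-(cyclopropylsulfonyl)pyrrolidin-3-yl in place of 1-((hydroxymethyl)carbonyl)piperidin-3-yl on an aromatic nitrogen. The rest of compound 3 is kept, so compound 4 carries the same 1-(cyclopropylsulfonyl)pyrrolidin-3-yl that compound 1 carries, and differs from compound 1 only by the (4-fluorophenyl)amino group in place of the unsubstituted phenylamino group.

Within the data shown here, since no pair of measured compounds differs in this single place, the size of the step has to be guessed from the two numbers at hand. The 1-(cyclopropylsulfonyl)pyrrolidin-3-yl is expected to bring compound 4 close to compound 1 because compound 1 gives 240 nM in this assay, so a step of a 3.0-fold lower number from compound 3 to compound 4 (0.48 log units; beyond the scatter) toward a lower number, beyond the scatter, is expected. Compound 4 is therefore estimated at 250 nM in this assay, with a range from 100 nM to 600 nM.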

Compound 4, half-maximal inhibitory concentration: 580 nM
For compound 4 the middle estimate is 2.3-fold (0.37 log units) below the measured one; the range from low to high includes it.
By their numbers in this assay, from the lowest: compound 1; then compounds 4 and 3 (each within the scatter of the next).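

At the aromatic nitrogen, 1-(cyclopropylsulfonyl)pyrrolidin-3-yl in place of 1-((hydroxymethyl)carbonyl)piperidin-3-yl gives a 1.3-fold lower number from compound 3 to compound 4 (0.11 log units; within the scatter) in this assay and so leaves the read-out unmoved, even though the ring size, the capping group and the count of hydrogen-bond donors all differ between the two substituents. Among these compounds, the second new step, fluoro in place of hydrogen on an aromatic carbon, gives a 2.4-fold higher number from compound 1 to compound 4 (0.38 log units; beyond the scatter) and is modest, but unlike the step on the nitrogen it lies beyond the scatter, which makes it the first single-place change in this set with a readable effect on the number. Nothing on hand explains either step.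

The compounds shown leave open which part of the substituent on the nitrogen matters: ring size and capping group change together here, and a piperidin-3-yl carrying the cyclopropylsulfonyl group would separate the two. They also leave open whether a chloro or a methoxy group in the place of the fluoro would move the number in the same direction, and how a free carboxylic acid or a simple amine would behave on the ring nitrogen.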